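The source may report more compounds than this note shows. Statements on the series, on what has been measured and on what is new or still open speak of the compounds shown alone.

Compound 1 `Cc1ccc(-c2cs/c(=N/NC(=O)CSc3nnnn3-c3ccccc3)n2-c2ccccc2)cc1` was tested in a functional assay on C6 cells (Rattus norvegicus) for cytotoxicity, read by MTT assay, with a stated time of 24 h, tested at 12 ug/mL (on this read-out lower numbers stand for a stronger effect and higher numbers for a weaker effect at the one concentration tested), where compound 1 gives 55.1%. Among the measured compounds shown here, its only measured companion is compound 2 `Cc1ccc(-c2cs/c(=N/NC(=O)CSc3nnnn3C)n2-c2ccccc2)cc1`, and in this assay compound 2 gives 68.8%. For the measured compounds named here, the single measured step, a number 13.7 percentage points higher from compound 1 to compound 2 (beyond the scatter), comes with the change methyl in place of phenyl on an aromatic nitrogen. On the numbers shown, compound 1 therefore stands lowest of the two, which on this read-out means the stronger effect at the one concentration tested.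

Compound 3 `O=C(CSc1nnnn1-c1ccccc1)N/N=c1/scc(-c2ccccc2)n1-c1ccccc1` has not yet been measured. It differs from compound 1 by hydrogen in place of methyl on an aromatic carbon, so the same difference, cut one bond further out, reads 4-methylphenyl to phenyl. The measured step from compound 1 to compound 2 concerns a different place, the substituent on the aromatic nitrogen, and so it does not speak directly to removing a methyl from the carbon ring. Going by the values given here, with no step at the relevant place to lean on, the expectation is a small step, a number 2.9 percentage points higher from compound 1 to compound 3 (within the scatter), that may well stay within the scatter. Compound 3 is therefore estimated at 58%, with a range from 45% to 72%.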

Compound 3, a percentage reported as activity, at one concentration (the size of the read-out at that concentration, not a potency): 47.1%
Estimate against measurement, compound 3: 10.9 percentage points above, and the stated range covers the measured number.
By their numbers in this assay, from the lowest: compounds 3 and 1 (each within the scatter of the next); then compound 2.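

In this assay, taking the methyl off the six-membered aromatic ring of carbon only, the change from 4-methylphenyl to phenyl, comes with a number 8 percentage points lower from compound 1 to compound 3 (within the scatter), so on this read-out compound 3 cannot be told apart from compound 1. This is the first information about this position, since the earlier pair spoke only to the group on the aromatic nitrogen, where a number 13.7 percentage points higher from compound 1 to compound 2 (beyond the scatter) did reach beyond the scatter; among the compounds shown, the change on the nitrogen therefore registers clearly, while the change on the carbon ring does not. No measurement shown offers an explanation for either result.

Hydrogen and methyl are only two close neighbours at this position, so it remains open whether a group such as a methoxy, a chlorine, an amine or a carboxylic acid in the same place would move the number beyond the scatter. It is also open whether phenyl in place of 4-methylphenyl would give a similar result in compound 2, with its methyl on the aromatic nitrogen, and a single tested concentration cannot show how the potencies of these compounds compare.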